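The source may report more compounds than this note shows. Statements on the series, on what has been measured and on what is new or still open speak of the compounds shown alone.

Measured so far:
- compound 1, `COc1cc(-c2nn(-c3cccc(NC(=O)c4cccc(C(F)(F)F)c4)c3)cc2-c2ccncc2)ccc1Cl`: 4560 nM
- compound 2, `COc1cc(-c2nn(-c3cccc(NC(=O)Nc4ccc(Cl)c(Cl)c4)c3)cc2-c2ccncc2)ccc1Cl`: 2270 nM
- compound 3, `COc1cc(-c2nn(-c3cccc(NC(=O)Nc4ccc(Cl)c(C(F)(F)F)c4)c3)cc2-c2ccncc2)ccc1Cl`: 4420 nM

All three were tested in a functional assay on MDA-MB-468 cells (Homo sapiens) for inhibition, read by sulforhodamine B assay, with a stated time of 48 h; on this read-out lower numbers stand for stronger inhibition of growth and higher numbers for weaker inhibition of growth. Among these three numbers compound 3 holds the second highest; its nearest neighbour is compound 1, its furthest compound 2, and both gaps, a 1.0-fold lower number from compound 1 to compound 3 (0.01 log units; within the scatter) and a 1.9-fold higher number from compound 2 to compound 3 (0.29 log units; within the scatter), stay within the scatter, so the three compounds cannot be told apart on this read-out.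

Compound 4, `COc1cc(-c2nn(-c3cccc(NC(=O)c4ccccc4)c3)cc2-c2ccncc2)ccc1Cl`, differs from compound 3 by phenyl in place of (4-chloro-3-(trifluoromethyl)phenyl)amino on a carbonyl carbon. For the measured compounds named here, two measured steps bear on this. The step of a 1.0-fold lower number from compound 1 to compound 3 (0.01 log units; within the scatter) shows that exchanging the group on the carbonyl carbon between a directly attached aromatic ring and an amino-linked one changes nothing beyond the scatter, and a 2.0-fold lower number from compound 1 to compound 2 (0.30 log units; within the scatter) points the same way. Going by the values given here, no measured step removes the chloro and trifluoromethyl groups altogether, which is the other part of this change, so that part rests on no data. The expected step of a 1.5-fold higher number from compound 3 to compound 4 (0.17 log units; within the scatter) is therefore small, with a wide range. Compound 4 is estimated at 6500 nM, between 2200 nM and 20000 nM.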

Compound 4, concentration for total growth inhibition: 3420 nM
Compound 4: middle estimate off by 1.9-fold (0.28 log units), on the high side; the measured number falls inside the stated range.
By their numbers in this assay, from the lowest: compounds 2, 4, 3 and 1 (each within the scatter of the next).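

In this assay, replacing (4-chloro-3-(trifluoromethyl)phenyl)amino with plain phenyl on the carbonyl carbon gives a 1.3-fold lower number from compound 3 to compound 4 (0.11 log units; within the scatter), and making the same exchange for the (3,4-dichlorophenyl)amino group gives a 1.5-fold higher number from compound 2 to compound 4 (0.18 log units; within the scatter). The part of the change that no earlier pair covered, hydrogen in place of trifluoromethyl on an aromatic carbon, gives a 1.3-fold lower number from compound 1 to compound 4 (0.12 log units; within the scatter), so among these four compounds, a bare phenyl ring on the carbonyl carbon cannot be told apart from the substituted rings. No measurement available here explains this lack of a readable difference.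

As far as these compounds go, it remains open whether an amine or a carboxylic acid on that phenyl ring would shift the number beyond the scatter. The same question applies to a longer chain in place of the ring on the carbonyl carbon.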